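The source may report more compounds than this note shows. Statements on the series, on what has been measured and on what is new or still open speak of the compounds shown alone.

Values in a functional assay on THP-1 cells (Homo sapiens) for inhibition, read by ELISA, with stated times of 1 h and 18 h; on this read-out lower numbers stand for stronger inhibition and higher numbers for weaker inhibition:
- Compound 1 `NC(=O)[C@@H]1[C@H](Nc2nc(Nc3cccc(C(=O)N4CCCC4)c3)ncc2C2CC2)[C@H]2C=C[C@@H]1C2`: 90 nM
- Compound 2 `NC(=O)[C@@H]1[C@H](Nc2nc(Nc3cccc(C(=O)N4CCCC4)c3)ncc2-c2ccc(F)cc2)[C@H]2C=C[C@@H]1C2`: 460 nM
- Compound 3 `N#Cc1cccc(-c2cnc(Nc3cccc(C(=O)N4CCCC4)c3)nc2N[C@H]2[C@@H](C(N)=O)[C@@H]3C=C[C@H]2C3)c1`: not yet measured

Compound 2 has the higher number of the two, at 460 nM, which makes it the weaker inhibitor. Compound 3 differs from it as follows: 3-cyanophenyl in place of 4-fluorophenyl on an aromatic carbon. For the measured compounds named here, the only measured step at this place is a 5.1-fold higher number from compound 1 to compound 2 (0.71 log units; beyond the scatter), a modest change that replaced cyclopropyl with an aromatic ring. Going by the values given here, the new change keeps a six-membered aromatic ring of carbon only and swaps its substituent, and no measured compound shows the effect of such a swap. A step beyond the scatter in this assay is therefore not expected, in either direction. The estimate amounts to a 1.2-fold lower number from compound 2 to compound 3 (0.06 log units; within the scatter), an expected change within the scatter. Compound 3 is expected at 400 nM, with an estimated range of 150 nM to 1000 nM.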

Compound 3, half-maximal inhibitory concentration: 280 nM
Compound 3: the middle estimate sits 1.4-fold (0.15 log units) above what was measured, within the range that was stated.
By their numbers in this assay, from the lowest: compound 1; then compounds 3 and 2 (each within the scatter of the next).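

In this assay, 3-cyanophenyl in place of 4-fluorophenyl gives a step within the scatter (a 1.6-fold lower number from compound 2 to compound 3 (0.22 log units; within the scatter)), so at this position the two aryl groups are not told apart, although the entering group brings a nitrile and a hydrogen-bond acceptor that the leaving group lacks. The gap to cyclopropyl now appears with a second aryl group (a 3.1-fold higher number from compound 1 to compound 3 (0.49 log units; beyond the scatter)), which leaves compound 1 as the strongest inhibitor of the three. No supporting data bear on the reason for this gap.

As far as these compounds go, whether the gap belongs to cyclopropyl alone or also holds for methyl or isopropyl stays open. Equally open, from the compounds shown here alone, are unsubstituted phenyl, which would separate the ring from its substituents, and an amine or a carboxylic acid at this position.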